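Adding a second chloro group to compound 2

This account rests on a few compounds, and the source may have more. Where it says the series, first, only, none or still open, it means among the compounds named here.

Compound 1 `Nc1ncc(-c2ccnc(F)c2)c(C2CC2)n1`: > 100000 nM, a limit
Compound 2 `Nc1ncc(-c2ccnc(Cl)c2)c(C2CC2)n1`: > 100000 nM, a limit
Compound 3 `Nc1ncc(-c2cc(Cl)nc(Cl)c2)c(C2CC2)n1`: not yet measured

Both values come from a functional assay on CUTLL1 cells (Homo sapiens) for inhibition, read by resazurin assay, with a stated time of 48 h, in the absence of a further agent; a higher number here means that more compound is needed for the effect, a lower number that less compound is needed. Neither is a number, and together they make up (the limit of > 100000 nM in this assay, at which 2 of the 2 values shown sit). Compound 2 gives > 100000 nM, which is a limit of this assay.

Compound 3 keeps the chloro group of compound 2 and gains a second one, a chloro in place of hydrogen on an aromatic carbon.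

Among the compounds with values here, only one measured step bears on this change. It is a step that the two limits leave unreadable from compound 1 to compound 2, which also concerns a halogen on the same ring but gives no size to carry over. The data therefore fix neither the size nor the direction of the new step. The most cautious expectation is that compound 3 stays close to the limit, with a modest move towards lower numbers possible. The expected change is an at least 2.5-fold lower number from compound 2 to compound 3 (0.39 log units; beyond the scatter). For compound 3 the estimated value is 40000 nM, with an expected range from 8000 nM to 100000 nM.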

Compound 3, half-maximal effective concentration: 10000 nM
Compound 3: the middle estimate sits 4.0-fold (0.60 log units) above what was measured; the range from low to high includes it.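

In this assay, within the data shown here, adding a second chloro group gives the first readable number, with an at least 10-fold lower number from compound 2 to compound 3 (1.00 log units; beyond the scatter). This shows that a chloro in place of hydrogen at this position, next to the ring nitrogen and meta to a chloro group, can bring a compound off the limit and into the range where the assay gives a number, something the earlier pair could not show, as the step between compound 1 and compound 2 cannot be read. Compound 3 is therefore the only compound here with a number, and the other two values are limits, not numbers: the limit of > 100000 nM in this assay, at which 2 of the 3 values shown sit.

On these data alone, it remains open whether this drop depends on chloro itself or whether another group at the same position, such as a methyl group, an amine or a methoxy group, would lower the number as well, or lower it further. Also open, as far as these compounds go, is whether the second chloro group needs the first one, which a compound carrying chloro only at the new position, with hydrogen at the old one, could settle.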